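Hydroxamate series: solubility of a sulfone analogue

The source may hold more compounds than are shown below. What is called first, only, known or untested is meant among the compounds shown, and "the series" means these compounds.

Measured compounds:
compound 1 `C#CCNC(=O)C[C@H](NC(=O)c1ccc(C#Cc2ccccc2)cc1)C(=O)NO`, 8000 nM
compound 2 `O=C(NC1(C(=O)NO)CCS(=O)(=O)CC1)c1ccc(C#Cc2ccccc2)cc1`, 2000 nM

In a physicochemical assay for solubility (on this read-out higher numbers stand for higher solubility and lower numbers for lower solubility), compound 1 gives 8000 nM, the higher of the two numbers; compound 2 gives 2000 nM, and the gap between the two lies beyond the usual scatter. Compound 3 `CS(=O)(=O)C[C@H](NC(=O)c1ccc(C#Cc2ccccc2)cc1)C(=O)NO` has not yet been measured in this assay. Its structure departs from compound 1 in one place: methylsulfonyl in place of propargylcarbamoyl on a saturated chain carbon, two bonds along the chain from an amide-type nitrogen and a carbonyl carbon. Within the data shown here, no measured pair covers this change, so the step of a 1.3-fold lower number from compound 1 to compound 3 (0.12 log units; within the scatter) is expected to be a small decrease, close to the scatter. For compound 3 the estimated value in this assay is 6000 nM, within the range 2500 nM to 15000 nM.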

Compound 3, solubility: 2000 nM
For compound 3 the middle estimate is 3.0-fold (0.48 log units) above the measured one, and the stated range ends above it.
By their numbers in this assay, from the lowest: compounds 2 and 3 (each within the scatter of the next); then compound 1.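

In this assay, methylsulfonyl in place of propargylcarbamoyl on a saturated chain carbon gives a 4.0-fold lower number from compound 1 to compound 3 (0.60 log units; beyond the scatter) on the shared core. This position is therefore not silent on this read-out: the group carried on this chain carbon can move the number beyond the scatter. Nothing measured here explains the step.

As far as these compounds go, whether the step follows the departure of propargylcarbamoyl or the arrival of methylsulfonyl stays open. Also open, from the compounds shown here alone, is where an amine, a carboxylic acid or a longer chain at this carbon would fall relative to compound 1 and compound 3.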